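A new aryl group on a saturated ring carbon

The source may report more compounds than this note shows. Statements on the series, on what has been measured and on what is new or still open speak of the compounds shown alone.

Compound 1, `N#CC1=C(N)N(c2ccc(S(N)(=O)=O)cc2)C2=C(CCCC2)C1c1ccccc1O`: 50%
Compound 2, `N#CC1=C(N)N(c2ccc(S(N)(=O)=O)cc2)C2=C(CCCC2)C1/C=C/c1ccccc1`: 90%
Compound 3, `COc1ccccc1C1C(C#N)=C(N)N(c2ccc(S(N)(=O)=O)cc2)C2=C1CCCC2`: 50%

These three compounds share one core and differ only in the group on a saturated ring carbon. They were tested in a functional assay on Ehrlich cells (Mus musculus) for cytotoxicity, read by trypan blue exclusion, with a stated time of 2 h, tested at 50 ug/mL; on this read-out lower numbers stand for a weaker effect and higher numbers for a stronger effect at the one concentration tested. Compound 3 stands level with compound 1, the two together being the lowest of the three numbers; its nearest neighbour is compound 1, with no change at the digits printed from compound 1 to compound 3 (within the scatter), and its furthest is compound 2, with a number 40 percentage points lower from compound 2 to compound 3 (beyond the scatter).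

Compound 4, `N#CC1=C(N)N(c2ccc(S(N)(=O)=O)cc2)C2=C(CCCC2)C1c1cccc([N+](=O)[O-])c1`, is not yet measured. It differs from compound 3 in one place: 3-nitrophenyl in place of 2-methoxyphenyl on a saturated ring carbon.

Among the compounds with values here, two measured steps bear on this. The step of no change at the digits printed from compound 1 to compound 3 (within the scatter) shows that exchanging one substituent on the aromatic ring for another left the read-out unchanged. The large step of a number 40 percentage points higher from compound 1 to compound 2 (beyond the scatter) arose only when the whole aromatic ring was replaced by 2-phenylethenyl. Compound 4 keeps an aromatic ring of the same kind as compound 3 and changes only the substituent on it, so no step beyond the scatter is expected, at most a small rise. For compound 4 in this assay the estimate is 55%, in the range 35% to 80%, which means the expected step of a number 5 percentage points higher from compound 3 to compound 4 (within the scatter).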

Compound 4, a percentage reported as activity, at one concentration (the size of the read-out at that concentration, not a potency): 2%
The estimate for compound 4 lay 53 percentage points above the measured number; measured number outside the range, below it.
By their numbers in this assay, from the lowest: compound 4; then compounds 1 and 3 (each within the scatter of the next); then compound 2.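

In this assay, the group on the saturated ring carbon proves sensitive to what the aromatic ring carries, since 3-nitrophenyl in place of 2-methoxyphenyl gives a large fall (a number 48 percentage points lower from compound 3 to compound 4 (beyond the scatter)) and 3-nitrophenyl in place of 2-hydroxyphenyl gives one of the same size (a number 48 percentage points lower from compound 1 to compound 4 (beyond the scatter)). Earlier, only 2-phenylethenyl had moved the number away from the level shared by compound 1 and compound 3, and it moved it upward, whereas 3-nitrophenyl moves it the other way and opens the widest gap in the set (a number 88 percentage points lower from compound 2 to compound 4 (beyond the scatter)). Compound 4 is thus the weakest of the four at the one concentration tested, and the silent exchange of 2-hydroxyphenyl for 2-methoxyphenyl proves to be no general rule for changes on this aromatic ring.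

The step changes both the group on the ring and the number in its name, so the compounds shown leave open whether the fall follows the nitro group itself or its location, a question that 2-nitrophenyl, 3-methoxyphenyl or 3-aminophenyl would help to settle. Nothing available here gives a cause for the fall.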